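Halogen Swap on the Phenoxy Group Awaiting Its Number

The compounds below may be only part of what the source reports. "The series", "measured", "known", "first", "only" and "open" are said of these compounds alone.

Going by the values given here, compound 3 stands as the only compound in this small set with a reported number. In a functional assay on HepG2 cells (Homo sapiens) for antiproliferative activity, read by MTT assay, with a stated time of 72 h (a lower number here means a stronger inhibitor, a higher number a weaker inhibitor), compound 1, `Cc1nn(C)c(Oc2cccc(F)c2)c1/C=N\CCCCCCOc1cc2oc(=O)cc(C)c2cc1Cl`, gives a limit of the assay, > 25000 nM. Compound 2, `Cc1nn(C)c(Oc2ccc(F)cc2F)c1/C=N\CCCCCCOc1cc2oc(=O)cc(C)c2cc1Cl`, likewise gives a limit in this assay, > 25000 nM. Among the compounds with values here, compound 3, `Cc1nn(C)c(Oc2ccccc2Br)c1/C=N\CCCCCCOc1cc2oc(=O)cc(C)c2cc1Cl`, gives 24200 nM in this assay, the one number among the three. Compounds 1 and 2 sit at a limit of the assay (the limit of > 25000 nM in this assay, at which 2 of the 3 values shown sit). Compound 4, `Cc1nn(C)c(Oc2ccc(I)cc2)c1/C=N\CCCCCCOc1cc2oc(=O)cc(C)c2cc1Cl`, differs from compound 3 only in the aryl ether: 4-iodophenyl in place of 2-bromophenyl on an oxygen on an aromatic ring. The measured steps bear on this change only loosely: an at least 1.0-fold lower number from compound 1 to compound 3 (0.01 log units; that floor lies within the scatter) and an at least 1.0-fold lower number from compound 2 to compound 3 (0.01 log units; that floor lies within the scatter) carry floors that lie within the scatter, and a step that the two limits leave unreadable from compound 1 to compound 2. None of them shows a change of the phenoxy group moving the number beyond the scatter, and every value sits at or near the limit. The expectation in this assay is therefore no step beyond the scatter, a 1.0-fold higher number from compound 3 to compound 4 (0.01 log units; within the scatter), with a fair chance that only a limit is reported again. Compound 4 is estimated at 25000 nM with a range from 12000 nM to 60000 nM.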

Compound 4, half-maximal inhibitory concentration: 14200 nM
Compound 4: the middle estimate sits 1.8-fold (0.25 log units) above what was measured; the range from low to high includes it.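

In this assay, going by these compounds alone, the exchange of 2-bromophenyl for 4-iodophenyl gives the first step in this set with a number at both ends: a 1.7-fold lower number from compound 3 to compound 4 (0.23 log units; within the scatter). The other two steps to this compound are only floors, an at least 1.7-fold lower number from compound 2 to compound 4 (0.24 log units; that floor lies within the scatter) and an at least 1.7-fold lower number from compound 1 to compound 4 (0.24 log units; that floor lies within the scatter), so neither shows that the phenoxy group moves the number beyond the scatter. Compounds 1 and 2 remain at a limit of the assay, so they offer no number for comparison: the limit of > 25000 nM in this assay, at which 2 of the 4 values shown sit.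

The one readable step changes both the halogen and its place on the ring, and the compounds shown do not separate the two. They also leave open how the number would respond to a phenoxy ring carrying an amine or a carboxylic acid in place of a halogen.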